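The compounds below may be only part of what the source reports. "The series", "measured", "known", "first", "only" and "open" are said of these compounds alone.

Working notes on an ADME assay on microsomes from liver (Homo sapiens) for metabolic stability, read by LC-MS, using NADPH, with a stated time of 10 min, tested at 10 uM; on this read-out higher numbers stand for a longer-lived compound and lower numbers for a shorter-lived compound. Compound 1 `Nc1ncnc2c1c(Oc1cc(C(F)(F)F)ccn1)nn2[C@H]1CC[C@H](CO)CC1` gives > 2.41 h, which is a limit and not a number. Compound 2 `N#Cc1ccnc(Oc2nn([C@H]3C[C@@H](O)C3)c3ncnc(N)c23)c1` gives > 2.41 h, also a limit. Compound 3 `CC(C)(C)n1nc(Oc2cc(C#N)ccn2)c2c(N)ncnc21` gives > 2.41 h, again a limit. Compound 4 `Nc1ncnc2c1c(Oc1cc(C(F)(F)F)ccn1)nn2[C@@H]1CC[C@H](N)C1` is not yet measured and differs from compound 1 by this change: 3-aminocyclopentyl in place of 4-(hydroxymethyl)cyclohexyl on an aromatic nitrogen. Within the data shown here, the only measured step at that aromatic nitrogen is a step that the two limits leave unreadable from compound 2 to compound 3, so it offers no size to carry over. With compound 1, compound 2 and compound 3 all resting on (the limit of > 2.41 h in this assay, at which 3 of the 3 values shown sit), no step beyond the scatter is expected in this assay, and no direction can be assigned. The expected step is a step that the limit leaves unreadable from compound 1 to compound 4. Compound 4 is estimated at 2.5 h, with an expected range of 1.2 h to 5 h.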

Compound 4, half-life: > 2.41 h
Compound 4: a limit, no number; the forecaster's own chance of this, stated with the estimate: 70%; the middle value is on the limit's open side.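

No new step can be read between compound 1 and compound 4, since both give only a limit: the limit of > 2.41 h in this assay, at which 4 of the 4 values shown sit.

The compounds shown leave open the true half-life of each one in this assay, and whether 3-aminocyclopentyl in place of 4-(hydroxymethyl)cyclohexyl changes it at all.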